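A few compounds are considered here, and "the series" means these few. Any claim that something is new, unique, unknown or untested is made for them only; others in the source may bear on it.

Compound 1 `CCc1nnc(SCC(=O)c2ccc(Cl)cc2)n1N1C(=O)c2ccccc2C1=O`: > 200000 nM
Compound 2 `CCCc1nnc(SCC(=O)c2ccc(Cl)cc2)n1N1C(=O)c2ccccc2C1=O`: > 200000 nM

In a functional assay on A549 cells (Homo sapiens) for cytotoxicity, read by MTT assay, with a stated time of 48 h (on this read-out lower numbers stand for stronger inhibition and higher numbers for weaker inhibition), compound 1 gives only a limit, > 200000 nM. Compound 2 likewise gives only a limit in this assay, > 200000 nM, so where it stands cannot be fixed; both values sit at the limit of > 200000 nM in this assay, at which 2 of the 2 values shown sit. Compound 3 `CCCc1nnc(SCc2ccccc2Cl)n1N1C(=O)c2ccccc2C1=O` carries 2-chlorophenyl in place of (4-chlorophenyl)carbonyl on a saturated chain carbon bound to a sulfur. Going by the values given here, the single measured step, a step that the two limits leave unreadable from compound 1 to compound 2, touches a different site and is not readable, so no size can be drawn from it for this change. Compound 3 is therefore expected to give 200000 nM, between 50000 nM and 500000 nM, most likely as a limit again. The expected step is a number no higher from compound 2 to compound 3 (the limit leaves the size open).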

Compound 3, half-maximal inhibitory concentration: > 200000 nM
Compound 3 gave a limit, no number; the forecaster's own chance of this, stated with the estimate: 75%; the middle value sits exactly at the limit.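

Going by these compounds alone, compound 3 also gives only a limit in this assay, > 200000 nM, so no step from compound 2 to it can be read. The compounds shown leave open whether either change affects cytotoxicity, since all three sit at one limit: the limit of > 200000 nM in this assay, at which 3 of the 3 values shown sit.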